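Working notes: varying the aryl ketone ring in this series

The source may hold more compounds than are shown below. What is called first, only, known or untested is meant among the compounds shown, and "the series" means these compounds.

Measured compounds in an ADME assay on HEK293 cells (Homo sapiens) for cytotoxicity, read by MTT assay, with a stated time of 68 h; on this read-out lower numbers stand for stronger inhibition and higher numbers for weaker inhibition:
compound 1 `O=C(/C=C/c1cccc(OCc2ccccc2)c1)c1ccc(Br)cc1` gives 5400 nM
compound 2 `O=C(/C=C/c1cccc(OCc2ccccc2)c1)c1ccc([N+](=O)[O-])cc1` gives 59300 nM
compound 3 `O=C(/C=C/c1cccc(OCc2ccccc2)c1)c1ccccc1` gives 14100 nM

Compound 1 stands with the lowest number of the three. Its nearest neighbour is compound 3, with a 2.6-fold higher number from compound 1 to compound 3 (0.42 log units; beyond the scatter); the furthest is compound 2, with an 11-fold higher number from compound 1 to compound 2 (1.04 log units; beyond the scatter). The remaining step is a 4.2-fold lower number from compound 2 to compound 3 (0.62 log units; beyond the scatter).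

Compound 4 `O=C(/C=C/c1cccc(OCc2ccccc2)c1)c1ccc(Cl)c(Cl)c1Cl` differs from compound 1 in one place: 2,3,4-trichlorophenyl in place of 4-bromophenyl on a carbonyl carbon. For the measured compounds named here, no measured step exchanges one halogenated ring for another on the carbonyl carbon. The two steps that start from compound 1 both take the bromo away, one for hydrogen, shown by a 2.6-fold higher number from compound 1 to compound 3 (0.42 log units; beyond the scatter), and one for nitro, shown by an 11-fold higher number from compound 1 to compound 2 (1.04 log units; beyond the scatter), and both raise the number. Compound 4 keeps halogen on that ring, so neither step transfers directly, and the expectation is a number close to that of compound 1. Compound 4 is therefore expected to give about 4500 nM, with a range of 1500 nM to 13000 nM. The expected step is a 1.2-fold lower number from compound 1 to compound 4 (0.08 log units; within the scatter), which lies within the scatter.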

Compound 4, half-maximal inhibitory concentration: 2400 nM
Compound 4: the middle estimate sits 1.9-fold (0.27 log units) above what was measured, and the stated range covers the measured number.
By their numbers in this assay, from the lowest: compound 4; then compound 1; then compound 3; then compound 2.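

In this assay, exchanging one halogenated ring for another on the carbonyl carbon still moves the number: 2,3,4-trichlorophenyl in place of 4-bromophenyl gives a 2.3-fold lower number from compound 1 to compound 4 (0.35 log units; beyond the scatter) and places compound 4 lowest of the four. The same ring gives a 5.9-fold lower number from compound 3 to compound 4 (0.77 log units; beyond the scatter) against phenyl and a 25-fold lower number from compound 2 to compound 4 (1.39 log units; beyond the scatter) against 4-nitrophenyl, so both halogenated rings in the set, in compound 1 and compound 4, read lower than the phenyl of compound 3, with the nitro ring of compound 2 highest. No accompanying measurement bears on what lies behind these steps.

Open, as far as these compounds go, is whether the number follows the kind of halogen, the count of halogens or their placement, since this single exchange alters all three at once. Also open, from the compounds shown here alone, is how a ring carrying an amine or a carboxylic acid would read at this position.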